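Varying the amine on the chain from the aromatic oxygen

This account rests on a few compounds, and the source may have more. Where it says the series, first, only, none or still open, it means among the compounds named here.

The three measured compounds share one core and differ only in the amine-bearing chain on the oxygen on the aromatic ring. Compound 1 `CC(C)=CCc1cc(C(=O)Nc2cc3ccc(OCC4CCN(C)C4)c(C)c3oc2=O)ccc1O` gives 920 nM in a functional assay on SK-BR-3 cells (Homo sapiens) for antiproliferative activity; a lower number here means a stronger inhibitor, a higher number a weaker inhibitor. Compound 2 `CCNCCCOc1ccc2cc(NC(=O)c3ccc(O)c(CC=C(C)C)c3)c(=O)oc2c1C` gives 720 nM in this assay, a step of a 1.3-fold lower number from compound 1 to compound 2 (0.11 log units; within the scatter). Compound 3 `CC(C)=CCc1cc(C(=O)Nc2cc3ccc(OCCCN(C(C)C)C(C)C)c(C)c3oc2=O)ccc1O` gives 1600 nM in this assay; it stands with the highest number of the three, with a 1.7-fold higher number from compound 1 to compound 3 (0.24 log units; within the scatter) and a 2.2-fold higher number from compound 2 to compound 3 (0.35 log units; beyond the scatter). Only the latter step lies beyond the scatter.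

Compound 4 `CC(C)=CCc1cc(C(=O)Nc2cc3ccc(OCCCN(C)c4ccccc4)c(C)c3oc2=O)ccc1O` is not yet measured. Its change from compound 3 is methyl(phenyl)amino in place of diisopropylamino on a saturated chain carbon, three bonds along the chain from an oxygen on an aromatic ring. The step that bears most directly on it is the earlier amine swap at the same place, a 2.2-fold higher number from compound 2 to compound 3 (0.35 log units; beyond the scatter), which was modest; the other swap at this place, a 1.7-fold higher number from compound 1 to compound 3 (0.24 log units; within the scatter), lay within the scatter. Going by the values given here, no measured compound carries a six-membered aromatic ring on this nitrogen, so the direction of the new step is not indicated by the data. The expectation is therefore a step of a 1.3-fold lower number from compound 3 to compound 4 (0.12 log units; within the scatter), essentially none beyond the scatter, with a wide range. Compound 4 is expected to give 1200 nM in this assay, between 500 nM and 3000 nM.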

Compound 4, half-maximal inhibitory concentration: > 50000 nM
Compound 4: only a limit was reported; the forecaster's own chance of this, stated with the estimate: 5%; middle value at least 41-fold (1.61 log units) away from the limit.
By their numbers in this assay, from the lowest: compounds 2, 1 and 3 (each within the scatter of the next, the first and the last beyond it). At a limit, above all of these: compound 4.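

In this assay the value of compound 4 is a limit of the assay and not a number: the limit of > 50000 nM in this assay, at which 1 of the 4 values shown sits. Methyl(phenyl)amino, the only amine here with a six-membered aromatic ring on the nitrogen, brings an at least 31-fold higher number from compound 3 to compound 4 (1.49 log units; beyond the scatter) as well as an at least 69-fold higher number from compound 2 to compound 4 (1.84 log units; beyond the scatter) and an at least 54-fold higher number from compound 1 to compound 4 (1.73 log units; beyond the scatter) in the same stretch of the chain. Compounds 1, 2 and 3 had suggested a place where amine swaps move the number modestly at most, whereas compound 4 shows that this place is not indifferent to the group on the chain.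

Going by these compounds alone, with compound 4 as the only example, the data cannot separate the effect of the aromatic ring on the nitrogen from anything else that changes with this swap, and its limit leaves the true size of the step unknown. A benzyl(methyl)amino group or a morpholine on the same 3-carbon chain would show whether the large step belongs to the aryl amine alone or extends to other amines.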